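The compounds below may be only part of what the source reports. "The series", "measured", "known", "first", "only" and "open" are said of these compounds alone.

Among the compounds with values here, compound 1 `CCC(C(=O)N[C@@H](CC(=O)O)C(=O)CSCc1ccccc1)n1ccnc(NCC2COc3ccccc3O2)c1=O` is the only member of the series with a number in an assay for inhibition of Caspase-8 (Homo sapiens); on this read-out lower numbers stand for stronger inhibition and higher numbers for weaker inhibition: compound 1 gives 8220 nM. Compound 2 `CCCCCCN(C)CNCC(=O)[C@H](CC(=O)O)NC(=O)C(CC)n1cc(C(C)(CC)CC)nc(NCc2nonc2C)c1=O` reaches only a limit in this assay, > 10000 nM; this is the limit of the method and not a number (the limit of > 10000 nM in this assay, at which 1 of the 2 values shown sits). Compound 3 `CCC(C(=O)N[C@@H](CC(=O)O)C(=O)CSCc1ccccc1)n1ccnc(NCc2cncs2)c1=O` is not yet measured. It differs from compound 1 in one place: 1,3-thiazol-5-yl in place of 2,3-dihydro-1,4-benzodioxin-2-yl on a saturated chain carbon bound to a nitrogen on an aromatic ring. Within the data shown here, no measured step covers such a change, so no direction is supported; the step is expected to stay within the scatter, a 1.1-fold higher number from compound 1 to compound 3 (0.04 log units; within the scatter). For compound 3 the estimate is 9000 nM, spanning 3500 nM to 25000 nM.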

Compound 3, half-maximal inhibitory concentration: 6590 nM
The estimate for compound 3 lay 1.4-fold (0.14 log units) above the measured number; the range from low to high includes it.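

In this assay, replacing 2,3-dihydro-1,4-benzodioxin-2-yl with the smaller 1,3-thiazol-5-yl gives a 1.2-fold lower number from compound 1 to compound 3 (0.10 log units; within the scatter). On this single pair, the saturated chain carbon bound to a nitrogen on an aromatic ring accepts either group without a change beyond the scatter. Compound 2 reaches a limit and not a number, which marks the top of the measurable range: the limit of > 10000 nM in this assay, at which 1 of the 3 values shown sits.

On these data alone, whether any group at this position can give a step beyond the scatter remains open. A basic piperidine or a longer alkyl chain in place of 1,3-thiazol-5-yl would be an untested contrast.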